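Swapping the aryl arm on the oxadiazole

This account rests on a few compounds, and the source may have more. Where it says the series, first, only, none or still open, it means among the compounds named here.

Two compounds measured in an assay for inhibition of Amine oxidase [flavin-containing] B (Homo sapiens), read by fluorescence and spectrophotometry, using microsomes, with stated times of 30 min and 20 min (a higher number here means a weaker inhibitor, a lower number a stronger inhibitor), share the same core. Compound 1 `CC(C)c1noc(-c2ccc(C3=NCCN3)cc2)n1` gives 230 nM in this assay, and compound 2 `COc1cccc(-c2noc(-c3ccc(C4=NCCN4)cc3)n2)c1` gives 216 nM. Going by the values given here, compound 2 has the lowest of the two numbers, but its only neighbour is compound 1, and the step of a 1.1-fold lower number from compound 1 to compound 2 (0.03 log units; within the scatter) shows that the two cannot be told apart. Compound 3 `Cc1ccc(Cc2noc(-c3ccc(C4=NCCN4)cc3)n2)cc1` differs from compound 2 by 4-methylbenzyl in place of 3-methoxyphenyl on an aromatic carbon. Among the compounds with values here, only the step from compound 1 to compound 2 bears on this change, and it was within the scatter, so the position that carries the group appears to accept both a small branched chain and an aryl ring without a measurable shift. Compound 3 is therefore expected to show a step of a 1.2-fold higher number from compound 2 to compound 3 (0.06 log units; within the scatter) that stays within the scatter. The estimate for compound 3 in this assay is 250 nM, with a range from 100 nM to 700 nM.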

Compound 3, half-maximal inhibitory concentration: 3640 nM
For compound 3 the middle estimate is 15-fold (1.16 log units) below the measured one, outside the stated range (above it).
By their numbers in this assay, from the lowest: compounds 2 and 1 (each within the scatter of the next); then compound 3.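

In this assay, this position proves not to accept every group: the step of a 17-fold higher number from compound 2 to compound 3 (1.23 log units; beyond the scatter) is large, as is the step of a 16-fold higher number from compound 1 to compound 3 (1.20 log units; beyond the scatter), whereas 3-methoxyphenyl and isopropyl could not be told apart. The heavy-atom count does not account for the result, since 4-methylbenzyl and 3-methoxyphenyl have the same count and each has one six-membered aromatic ring; they differ in that only 3-methoxyphenyl carries an oxygen and a hydrogen-bond acceptor. No measurement shown here explains the rise in the number.

The swap alters the ring's attachment and its substituent together, so the compounds shown cannot say which of these carries the step. An unsubstituted benzyl or a 3-methoxybenzyl at this position would separate the two changes.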